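This account rests on a few compounds, and the source may have more. Where it says the series, first, only, none or still open, it means among the compounds named here.

In a functional assay on SMMC-7721 cells (Homo sapiens) for cytotoxicity, read by MTT assay, with a stated time of 24 h (on this read-out lower numbers stand for stronger inhibition and higher numbers for weaker inhibition), compound 1 (`O=C1/C(=C/c2cccnc2)CN(S(=O)(=O)c2ccc(C(F)(F)F)cc2)C/C1=C\c1ccccc1F`) gives 7900 nM and compound 2 (`O=C1/C(=C/c2ccncc2)CN(S(=O)(=O)c2ccc([N+](=O)[O-])cc2)C/C1=C\c1ccccc1F`) gives 15800 nM, so compound 2 stands within the usual scatter of compound 1. Compound 3 (`O=C1/C(=C/c2ccncc2)CN(S(=O)(=O)c2ccc(C(F)(F)F)cc2)C/C1=C\c1ccccc1F`) follows from compound 2 with trifluoromethyl in place of nitro on an aromatic carbon, para to a large group: trifluoromethyl in place of nitro on an aromatic carbon. Going by the values given here, no measured pair isolates this change, and no step beyond the scatter is expected in this assay. The estimated step is a 1.4-fold lower number from compound 2 to compound 3 (0.16 log units; within the scatter), which is expected to stay within the scatter. For compound 3 the estimated value is 11000 nM, with an expected range of 4500 nM to 26000 nM.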

Compound 3, half-maximal inhibitory concentration: 11100 nM
Compound 3: the middle estimate sits 1.0-fold (0.00 log units) below what was measured, within the range that was stated.
By their numbers in this assay, from the lowest: compounds 1, 3 and 2 (each within the scatter of the next).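

In this assay, trifluoromethyl in place of nitro on the aromatic carbon gives a 1.4-fold lower number from compound 2 to compound 3 (0.15 log units; within the scatter), and pyridin-4-yl in place of pyridin-3-yl on the double-bonded chain carbon gives a 1.4-fold higher number from compound 1 to compound 3 (0.15 log units; within the scatter). Going by these compounds alone, these are the first single-place comparisons, and neither change separates its pair beyond the scatter. No measurement shown bears on the reason for these results.

From the compounds shown here alone, whether an amine or a carboxylic acid on that aromatic carbon would step beyond the scatter stays open. The same holds for pyridin-2-yl on the chain carbon.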